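The source may hold more compounds than are shown below. What is called first, only, known or untested is meant among the compounds shown, and "the series" means these compounds.

For the measured compounds named here, in a functional assay on HeLa cells (Homo sapiens) for inhibition, read by cell counting, with a stated time of 4 days (a higher number here means a weaker inhibitor, a lower number a stronger inhibitor), compound 1 `C=C(Br)C(=O)Nc1cccc(-c2cn3nc(-c4ccc(F)cc4)sc3n2)c1` gives 870 nM and holds the lower of the two numbers measured so far; compound 2 `COc1ccc(-c2nn3cc(-c4cccc(N)c4)nc3s2)cc1OC` gives 26000 nM in this assay, a gap well beyond the scatter. Going by the values given here, no pair of measured compounds differing in a single place is available, so the step to compound 3 `C=C(Br)C(=O)Nc1cccc(-c2cn3nc(-c4cccs4)sc3n2)c1` rests on the structural change alone: thiophen-2-yl in place of 4-fluorophenyl on an aromatic carbon. A small step is expected, a 1.4-fold higher number from compound 1 to compound 3 (0.14 log units; within the scatter), none beyond the scatter or a slight rise in the number. For compound 3 the estimate in this assay is 1200 nM, with a range from 400 nM to 4000 nM.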

Compound 3, half-maximal inhibitory concentration: 670 nM
The estimate for compound 3 lay 1.8-fold (0.25 log units) above the measured number; the range from low to high includes it.
By their numbers in this assay, from the lowest: compounds 3 and 1 (each within the scatter of the next); then compound 2.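

In this assay, thiophen-2-yl in place of 4-fluorophenyl on this aromatic carbon gives a 1.3-fold lower number from compound 1 to compound 3 (0.11 log units; within the scatter). This position therefore accepts a five-membered aromatic ring with one hetero atom as well as a six-membered aromatic ring of carbon only, with no change in the number beyond the scatter. No evidence is available to explain why the two groups give such similar numbers. On these data alone, only these two aromatic rings can be compared at this position, so the effect of an amine, a carboxylic acid or a longer chain on this carbon stays open.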